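A few compounds are considered here, and "the series" means these few. Any claim that something is new, unique, unknown or untested is made for them only; others in the source may bear on it.

For the measured compounds named here, three related compounds have numbers so far in a functional assay on MCF7 cells (Homo sapiens) for cytotoxicity, read by MTT assay, with a stated time of 72 h (a higher number here means a weaker inhibitor, a lower number a stronger inhibitor), and they span a wide range. Compound 1 `COC(=O)c1sc2cc(OC)ccc2c1Nc1cc(OC)c(OC)c(OC)c1` gives 0.7 nM and compound 2 `COC(=O)c1sc2nc(C)ccc2c1Nc1cc(OC)c(OC)c(OC)c1` gives 0.53 nM and these two values lie within the usual scatter of each other. Compound 3 `CCOC(=O)c1sc2cccc(C)c2c1Nc1cc(OC)c(OC)c(OC)c1` gives 4150 nM as a far higher number, so compound 2 stands with compound 1 at the strong end of this small set. Compound 4 `COC(=O)c1sc2ncccc2c1Nc1cc(OC)c(OC)c(OC)c1` has hydrogen in place of methyl on an aromatic carbon, next to the ring nitrogen (hydrogen in place of methyl on an aromatic carbon). Going by the values given here, no measured pair shows this change alone, so only a small step towards a weaker inhibitor is expected, possibly none beyond the scatter. The estimate means a 2.8-fold higher number from compound 2 to compound 4 (0.45 log units; beyond the scatter) as the expected move. Compound 4 is estimated at 1.5 nM with an expected range from 0.2 nM to 30 nM on repeat measurement.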

Compound 4, half-maximal inhibitory concentration: 2640 nM
Beside the measured number, compound 4's estimate is 1800-fold (3.25 log units) below it, and the stated range ends below it.
By their numbers in this assay, from the lowest: compounds 2 and 1 (each within the scatter of the next); then compounds 4 and 3 (each within the scatter of the next).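

Swapping the methyl for hydrogen on this aromatic carbon, next to the ring nitrogen, gives a 5000-fold higher number from compound 2 to compound 4 (3.70 log units; beyond the scatter) in this assay, so a single carbon atom here separates the strong end of this set from the weak end. This first pair differing in one place shows that this position responds sharply to even so small a change. Nothing available explains the size of this step.

The compounds shown have only methyl and hydrogen at this carbon, so it stays open whether ethyl, methoxy or chlorine there would keep the strength of compound 2.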